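The source may hold more compounds than are shown below. What is called first, only, known or untested is meant among the compounds shown, and "the series" means these compounds.

For the measured compounds named here, compound 2 `COc1cc(N2C(N)=C(C#N)C(c3c(O)ccc4ccccc34)C3=C2CC(C)(C)CC3=O)cc(OC)c1OC` is the only compound of this small set with a number in a functional assay on Ehrlich cells (Mus musculus) for cytotoxicity; a higher number here means a weaker inhibitor, a lower number a stronger inhibitor: compound 2 gives 143000 nM. Compound 1 `COc1cc(N2C(N)=C(C#N)C(c3ccc(OC)c4ccccc34)C3=C2CC(C)(C)CC3=O)cc(OC)c1OC` was reported in this assay as "not active" (no number reported), with no number attached. Compound 3 `COc1cc(N2C(N)=C(C#N)C(c3cccc([N+](=O)[O-])c3)C3=C2CC(C)(C)CC3=O)cc(OC)c1OC` has not yet been tested. Compared with compound 2, it carries 3-nitrophenyl in place of 2-hydroxynaphthalen-1-yl on a saturated ring carbon. Going by the values given here, no step between measured compounds exists here, so the data give no guide to how a change of this kind shifts the half-maximal inhibitory concentration. Both known entries are weak, so a large gain is not anticipated. The step of a 1.0-fold higher number from compound 2 to compound 3 (0.02 log units; within the scatter) is expected to be small and may well lie within the scatter. Compound 3 is therefore expected to give roughly 150000 nM in this assay, somewhere between 40000 nM and 600000 nM, with a real chance that no number is obtained at all.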

Compound 3, half-maximal inhibitory concentration: "not active" (no number reported)
The entry for compound 3 holds no number, and the estimate cannot be compared.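

In this assay, for the compounds shown here, compound 3 carries no number, so no step from compound 2 to compound 3 can be read. No measurement shown explains this result. The compounds shown leave open how strongly the 3-nitrophenyl group and the 2-hydroxynaphthalen-1-yl group differ in their effect on these cells.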